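Exchanging the thiazole amide for a chlorophenyl amide

The source may report more compounds than this note shows. Statements on the series, on what has been measured and on what is new or still open speak of the compounds shown alone.

Of the compounds shown here, two sharing one core have been measured in a functional assay on HeLa cells (Homo sapiens) for antiproliferative activity, read by MTT assay, with a stated time of 72 h; a higher number here means a weaker inhibitor, a lower number a stronger inhibitor. Compound 1, `O=C(Nc1ccc(Cl)c(-c2nnc3c(Cl)cccn23)c1)c1ccc(C(F)(F)F)cc1F`, gives 61900 nM in this assay. Compound 2, `Cc1nc(C(=O)Nc2ccc(Cl)c(-c3nnc4c(Cl)cccn34)c2)cs1`, gives 79800 nM in this assay. Nothing separates the two on these numbers: the gap between compound 2 and compound 1 lies within the usual scatter of repeated measurements, so neither can be called the stronger or weaker inhibitor, and both sit in a weak range.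

Compound 3, `O=C(Nc1ccc(Cl)c(-c2nnc3c(Cl)cccn23)c1)c1ccc(Cl)cc1`, has not yet been measured in this assay. It differs from compound 2 in one place: 4-chlorophenyl in place of 2-methyl-1,3-thiazol-4-yl on a carbonyl carbon. Within the data shown here, with no step between measured compounds available, the only guide is that compound 1 and compound 2, which carry different aryl groups on the same carbonyl carbon, give numbers within the scatter of each other. From this the step from compound 2 to compound 3 is expected to be small, a 1.3-fold lower number from compound 2 to compound 3 (0.12 log units; within the scatter), with no clear direction beyond the scatter. Compound 3 is therefore estimated at 60000 nM in this assay, with a range from 20000 nM to 180000 nM.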

Compound 3, half-maximal inhibitory concentration: > 100000 nM
Compound 3: only a limit was reported; the forecaster's own chance of this, stated with the estimate: 20%; middle value at least 1.6-fold (0.22 log units) away from the limit.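

Compound 3 gives only a limit in this assay, > 100000 nM, and this is a limit of the assay and not a number. Among these compounds, this is the first step that can be read at this position, and exchanging 2-methyl-1,3-thiazol-4-yl for 4-chlorophenyl on a carbonyl carbon gives an at least 1.2-fold higher number from compound 2 to compound 3 (0.09 log units; that floor lies within the scatter), which shows that this change brings no gain here, although the printed floor alone does not place the step beyond the scatter. The true size of the step stays unknown, and it can be given only as a floor because the reading for compound 3 stops at a limit: the limit of > 100000 nM in this assay, at which 1 of the 3 values shown sits.

The compounds shown leave open whether any group on this carbonyl carbon can bring the number out of the weak range, for example a phenyl ring carrying a carboxylic acid or a piperidine with its basic amine. They also leave open how much the chlorine itself contributes to the result for compound 3, a question that a plain phenyl group on the same carbonyl carbon would address.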